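Methyl in Place of Formyl: What to Expect of Compound 3

A few compounds are considered here, and "the series" means these few. Any claim that something is new, unique, unknown or untested is made for them only; others in the source may bear on it.

Measured so far:
Compound 1, `COC(=O)c1cc(=O)c2c(OC)cc(OC)cc2[nH]1`: > 34400 nM
Compound 2, `COc1ccc(-c2cc(=O)c3c(OC)cc(OC)cc3n2S(=O)(=O)c2ccc(C=O)cc2)cc1`: > 34400 nM

Both values come from a functional assay on KOPN-8 cells (Homo sapiens) for antiproliferative activity, with a stated time of 72 h; a lower number here means that less compound is needed, a higher number that more compound is needed for the effect. For compound 1 the value > 34400 nM is a limit of the assay, not a number. For compound 2 the value > 34400 nM is likewise only a limit. Among the compounds with values here, compound 2 therefore stands at the limit of > 34400 nM in this assay, at which 2 of the 2 values shown sit, and since no step between measured compounds is available, nothing can be said yet about how changes on the shared core move the read-out.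

Compound 3, `COc1ccc(-c2cc(=O)c3c(OC)cc(OC)cc3n2S(=O)(=O)c2ccc(C)cc2)cc1`, has not been measured. It differs from compound 2 by methyl in place of formyl on an aromatic carbon. This is a small change at the outer edge of the molecule, and the step from compound 2 to compound 3 is expected to stay within the usual scatter, a step that the limit leaves unreadable from compound 2 to compound 3. Compound 3 is thus expected to give about 50000 nM. For compound 3 the expected range is estimated to run from 15000 nM to 200000 nM, most likely reported again as a limit.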

Compound 3, half-maximal effective concentration: > 44800 nM
Compound 3: only a limit was reported; the forecaster's own chance of this, stated with the estimate: 80%; the middle value does not contradict the limit.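

Compound 2 and compound 3 are both reported only as limits, and no step can be read between them. The compounds shown leave open whether methyl in place of formyl moves the read-out at all, and whether any change on the shared core would give a measurable number.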